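The compounds below may be only part of what the source reports. "The series", "measured", "known", "first", "only" and "open" are said of these compounds alone.

Measured compounds:
- compound 1, `COc1ccc(/C=C/C(=O)c2cc(-c3ccc(OC)c(OC)c3)n3nc(-c4ccccc4)cc3n2)cc1`, in an ADME assay on HEK293 cells (Homo sapiens) for antiproliferative activity, read by MTT assay, with a stated time of 24 h (on this read-out higher numbers stand for weaker inhibition and lower numbers for stronger inhibition), compound 1 gives 50700 nM
- compound 2, `COc1ccc(/C=C/C(=O)c2cc(-c3cc(OC)c(OC)c(OC)c3)n3nc(-c4ccccc4)cc3n2)cc1`, in this assay compound 2 gives 46600 nM

Compound 1 has the highest of the two numbers, and its nearest neighbour, compound 2, differs by a 1.1-fold lower number from compound 1 to compound 2 (0.04 log units; within the scatter), a gap within the scatter, so the two compounds cannot be ordered.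

Compound 3, `COc1ccc(-c2cc(/C=C/C(=O)c3ccc(Cl)cc3)nc3cc(-c4ccccc4)nn23)cc1OC`, has not yet been measured. It differs from compound 1 in one place: 2-((4-chlorophenyl)carbonyl)ethenyl in place of (2-(4-methoxyphenyl)ethenyl)carbonyl on an aromatic carbon. Among the measured compounds shown here, the one measured step, from compound 1 to compound 2, concerns a methoxy group on a different ring and says nothing about turning the chain around or exchanging methoxy for chlorine at its far end. For the measured compounds named here, with no step that bears on this change, the expectation is a number close to that of compound 1, with no movement beyond the scatter, written as a 1.1-fold lower number from compound 1 to compound 3 (0.05 log units; within the scatter). Compound 3 is therefore estimated at 45000 nM, within a range of 20000 nM to 100000 nM.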

Compound 3, half-maximal inhibitory concentration: 44100 nM
Compound 3: middle estimate off by 1.0-fold (0.01 log units), on the high side; low and high end bracket the measured number.
By their numbers in this assay, from the lowest: compounds 3, 2 and 1 (each within the scatter of the next).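

Placing 2-((4-chlorophenyl)carbonyl)ethenyl in place of (2-(4-methoxyphenyl)ethenyl)carbonyl, on the aromatic carbon next to the ring nitrogen, gives a 1.1-fold lower number from compound 1 to compound 3 (0.06 log units; within the scatter) in this assay, so compound 1 and compound 3 cannot be ordered. Unlike the earlier methoxy step on a different ring, this change concerns the chain itself: the carbonyl moves to the far side of the double bond, and a chlorine stands where the chain previously carried a methoxy group, yet the result stays within the scatter. No supporting measurement is available to explain this result.

As far as these compounds go, because the chain's direction and its end group differ together, the effect of each alone remains open. Also open, from the compounds shown here alone, is how this position would respond to an amine, a carboxylic acid or a longer chain.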